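The source may hold more compounds than are shown below. What is called first, only, known or untested is meant among the compounds shown, and "the series" means these compounds.

Measured so far:
compound 1, `Nc1ccccc1NC(=O)c1ccc(CSC(=S)N2CCN(Cc3ccccn3)CC2)cc1`: 23.4%
compound 2, `CN(Cc1cccnc1)C(=S)SCc1ccc(C(=O)Nc2ccccc2N)cc1`: 45.9%

In a functional assay on MGC-803 cells (Homo sapiens) for antiproliferative activity, read by CCK-8 assay, with a stated time of 72 h, tested at 2 uM (a lower number here means a weaker effect, a higher number a stronger effect of the compound at the concentration tested), compound 1 stands lowest of the two numbers shown. Its nearest neighbour, compound 2, gives 45.9%, a number higher by a margin that lies beyond the usual scatter. Among the measured compounds shown here, no pair of measured compounds differs in a single place, so no step size has yet been observed, and compound 2 differs from compound 1 in more than one place.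

Compound 3, `Cc1ccc(N2CCN(C(=S)SCc3ccc(C(=O)Nc4ccccc4N)cc3)CC2)cc1`, is not yet measured. Relative to compound 1 the change is 4-methylphenyl in place of (pyridin-2-yl)methyl on an amine nitrogen in a ring. For the measured compounds named here, no measured pair speaks to this exchange. The expected step of a number 11.6 percentage points higher from compound 1 to compound 3 (beyond the scatter) is a modest rise, with a result within the scatter of compound 1 held open as a real possibility. The estimate for compound 3 is accordingly 35%, and compound 3 is expected to fall between 15% and 60%.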

Compound 3, a percentage reported as inhibition, at one concentration (the size of the read-out at that concentration, not a potency): 33.4%
Compound 3: the middle estimate sits 1.6 percentage points above what was measured; the range from low to high includes it.
By their numbers in this assay, from the lowest: compounds 1 and 3 (each within the scatter of the next); then compound 2.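

In this assay, 4-methylphenyl in place of (pyridin-2-yl)methyl on an amine nitrogen in a ring gives a number 10 percentage points higher from compound 1 to compound 3 (within the scatter), the first single-place step read in the series. At this position, then, a six-membered aromatic ring of carbon only in place of one with a hetero atom, with the hydrogen-bond acceptor of the leaving group gone, produces no change that stands clear of the scatter. No measurement is at hand that would explain this step.

Going by these compounds, whether a group without an aromatic ring on this nitrogen, such as a cyclohexyl or a short alkyl chain, would move the read-out beyond the scatter remains open. So does the effect of a carboxylic acid or a methoxy group on the phenyl ring.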